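Three Thioethers on a Shared Core, and a Fourth to Come

The source may hold more compounds than are shown below. What is called first, only, known or untested is meant among the compounds shown, and "the series" means these compounds.

Three compounds share one core and differ only in the group attached through a sulfur. Compound 1, `CC(C)Sc1n[nH]c(-n2[se]c3ccccc3c2=O)n1`, carries an isopropyl on that sulfur; in an ADME assay on L929 cells (Mus musculus) for antiproliferative activity, read by CCK-8 assay, with a stated time of 48 h (a higher number here means a weaker inhibitor, a lower number a stronger inhibitor), compound 1 gives 37100 nM. Compound 2, `Cc1ccccc1CSc1n[nH]c(-n2[se]c3ccccc3c2=O)n1`, carries a 2-methylbenzyl and gives 15600 nM. Compound 3, `CCCSc1n[nH]c(-n2[se]c3ccccc3c2=O)n1`, carries a propyl and gives 31800 nM. Among these three numbers compound 3 stands second highest: its nearest neighbour is compound 1, with a 1.2-fold lower number from compound 1 to compound 3 (0.07 log units; within the scatter), and its furthest is compound 2, with a 2.0-fold higher number from compound 2 to compound 3 (0.31 log units; beyond the scatter).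

Compound 4, `Cc1cccc(CSc2n[nH]c(-n3[se]c4ccccc4c3=O)n2)c1`, is not yet measured. It differs from compound 3 in one place: 3-methylphenyl in place of ethyl on a saturated chain carbon bound to a sulfur.

For the measured compounds named here, two measured steps bear on this. Replacing a small alkyl with a methyl-bearing benzyl gave a 2.4-fold lower number from compound 1 to compound 2 (0.38 log units; beyond the scatter), and the reverse exchange gave a 2.0-fold higher number from compound 2 to compound 3 (0.31 log units; beyond the scatter). Both point the same way: the aromatic arm lowers the number modestly. The new arm carries its methyl at a different spot on the ring than in compound 2, so the size may differ, but the direction is expected to hold. Compound 4 is therefore expected to show a 2.1-fold lower number from compound 3 to compound 4 (0.33 log units; beyond the scatter), an estimated 15000 nM with a likely range from 7000 nM to 35000 nM.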

Compound 4, half-maximal inhibitory concentration: > 50000 nM
Compound 4 gave a limit, no number; the forecaster's own chance of this, stated with the estimate: 5%; middle value at least 3.3-fold (0.52 log units) away from the limit.
By their numbers in this assay, from the lowest: compound 2; then compounds 3 and 1 (each within the scatter of the next). At a limit, above all of these: compound 4.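

In this assay compound 4 reaches only a limit of the assay, not a number: the limit of > 50000 nM in this assay, at which 1 of the 4 values shown sits.

The clearest reading comes from the pair that differs only in the ring substituent, 3-methylphenyl in place of 2-methylphenyl, with an at least 3.2-fold higher number from compound 2 to compound 4 (0.50 log units; beyond the scatter), so a methyl-bearing benzyl on the sulfur does not by itself lower the number, and the low value of compound 2 is tied to its own 2-methylbenzyl arm. On these data alone, the comparisons with the small alkyl chains say less, with an at least 1.5-fold higher number from compound 3 to compound 4 (0.19 log units; that floor lies within the scatter) and an at least 1.3-fold higher number from compound 1 to compound 4 (0.12 log units; that floor lies within the scatter); both floors lie within the scatter, so the true size of these gaps is unknown, but 3-methylbenzyl gives no sign of the lower number that the 2-methylbenzyl of compound 2 showed.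

As far as these compounds go, how far past the limit compound 4 truly lies remains open, so the full size of all three steps is unknown. Also open, from the compounds shown here alone, is how a plain benzyl with no methyl, or a butyl chain, would read on the same sulfur, and so whether the 2-methylbenzyl of compound 2 or the 3-methylbenzyl of compound 4 is the unusual case.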